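This account rests on a few compounds, and the source may have more. Where it says the series, first, only, none or still open, it means among the compounds named here.

Measured so far:
- compound 1, `CCCCCCCCc1ccc(OCC(=O)Cn2nnc(C)n2)cc1`: 27 nM
- compound 2, `CCCCCCCCc1ccc(OCC(=O)Cn2nnc(-c3cccc(Cl)c3)n2)cc1`: 24 nM

In an assay on microsomes from brain for inhibition of Fatty-acid amide hydrolase 1 (Rattus norvegicus), read by fluorescence and HPLC, with a stated time of 60 min (a lower number here means a stronger inhibitor, a higher number a weaker inhibitor), compound 2 gives the lowest of the two numbers, but the step of a 1.1-fold lower number from compound 1 to compound 2 (0.05 log units; within the scatter) lies within the scatter, so the two cannot be ordered. Compound 3, `CCCCCCCCc1ccc(OCC(=O)Cn2nnc(-c3cccc(C(=O)OC)c3)n2)cc1`, carries methoxycarbonyl in place of chloro on an aromatic carbon. Within the data shown here, the only measured step, the one from compound 1 to compound 2, changed the substituent on the same aromatic carbon and stayed within the scatter; no step here tests methoxycarbonyl against chloro directly. The expected step is therefore a 1.3-fold higher number from compound 2 to compound 3 (0.10 log units; within the scatter), none beyond the scatter. Compound 3 is estimated at 30 nM, in the range 12 nM to 80 nM.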

Compound 3, half-maximal inhibitory concentration: 34 nM
The estimate for compound 3 lay 1.1-fold (0.05 log units) below the measured number, within the range that was stated.
By their numbers in this assay, from the lowest: compounds 2, 1 and 3 (each within the scatter of the next).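

In this assay, methoxycarbonyl in place of chloro gives a 1.4-fold higher number from compound 2 to compound 3 (0.15 log units; within the scatter), and 3-(methoxycarbonyl)phenyl in place of methyl gives a 1.3-fold higher number from compound 1 to compound 3 (0.10 log units; within the scatter). Across these three compounds, the position therefore accepts a group carrying hydrogen-bond acceptors, with no step beyond the scatter. No available evidence bears on why the numbers stay together.

From the compounds shown here alone, whether a carboxylic acid or an amine on this aromatic carbon would move the number beyond the scatter remains open. So does whether these substituents would still make no measurable difference with a shorter chain on the core.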